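Phenol to methyl ether on two related cores

A few compounds are considered here, and "the series" means these few. Any claim that something is new, unique, unknown or untested is made for them only; others in the source may bear on it.

Compound 1 `COc1ccc(-c2cc3ccccc3c(-c3ccc(O)cc3)n2)cc1` gives 1220 nM in a functional assay on T47D cells (Homo sapiens) for cytotoxicity, read by CCK-8 assay and cell counting, with a stated time of 72 h; a lower number here means a stronger inhibitor, a higher number a weaker inhibitor. Compound 2 `COc1ccc(-c2cc3ccccc3c(-c3ccc(OC)cc3)n2)cc1` differs from it by methyl in place of hydrogen on an oxygen on an aromatic ring; in this assay compound 2 gives 850 nM, and the step is a 1.4-fold lower number from compound 1 to compound 2 (0.16 log units; within the scatter). Compound 3 `COc1ccc(-c2cc3cc(C)ccc3c(-c3ccc(O)cc3)n2)cc1OC` shows the highest number of the three, 4420 nM in this assay, beyond the scatter from both compound 1 and compound 2. How the core of compound 3 differs from the core of compound 1 is not broken down here. Compound 4 `COc1ccc(-c2nc(-c3ccc(OC)c(OC)c3)cc3cc(C)ccc23)cc1` has not been measured; it differs from compound 3 by methyl in place of hydrogen on an oxygen on an aromatic ring, the same change as between compound 1 and compound 2, at a place described in the same words. Within the data shown here, the only precedent for this change is a 1.4-fold lower number from compound 1 to compound 2 (0.16 log units; within the scatter), measured on a different core, so the expected size of the new step is a 1.4-fold lower number from compound 3 to compound 4 (0.14 log units; within the scatter), a shift within the scatter. Compound 4 is expected to give about 3200 nM in this assay, with a likely range from 1500 nM to 7000 nM, pending the actual measurement.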

Compound 4, half-maximal inhibitory concentration: 3340 nM
Estimate against measurement, compound 4: 1.0-fold (0.02 log units) below; the measured number falls inside the stated range.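

In this assay, hydroxy to methoxy on the second core gives a 1.3-fold lower number from compound 3 to compound 4 (0.12 log units; within the scatter), so the step seen on the core of compound 1 recurs here with no detectable difference in size. Set side by side, the two steps agree: the same change on two cores in this assay, a 1.4-fold lower number (0.16 log units; within the scatter) from compound 1 to compound 2 and a 1.3-fold lower number (0.12 log units; within the scatter) from compound 3 to compound 4, 1.1-fold (0.04 log units) apart, within the scatter of two such steps

This shows that, on these two cores, the swap from 4-hydroxyphenyl to 4-methoxyphenyl leaves the number within the scatter, but with both steps that small it does not show that the methyl adds anything to cytotoxicity, and two pairs cannot establish a rule for the whole series.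

The compounds shown leave open whether anything other than methyl on that oxygen would move the number beyond the scatter, for example a longer chain such as propyl, a chain ending in an amine, or a carboxylic acid in place of the hydroxy. They also leave open whether the same swap stays this small on any further core.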